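Replacing a Propyl Chain by a Cyanophenyl Ring

This account rests on a few compounds, and the source may have more. Where it says the series, first, only, none or still open, it means among the compounds named here.

The shared core of this series carries a substituted chain on a saturated chain carbon bound to an aromatic carbon of the imidazole-type fragment. Compound 1 `O=C(O)c1ccccc1-c1ccc(CCc2ncc(CC3CCCCCC3)[nH]2)cc1` bears a cycloheptyl there and in an in vitro functional assay on cells for agonist activity at Bombesin receptor subtype-3 (Mus musculus), read by luminescence and calcium flux (on this read-out lower numbers stand for an effect already at smaller amounts and higher numbers for an effect only at larger amounts of compound), compound 1 gives 5.7 nM. Among the compounds with values here, compound 2 `CCCCc1cnc(CCc2ccc(-c3ccccc3C(=O)O)cc2)[nH]1` carries a propyl instead and in this assay compound 2 gives 93 nM, the highest of the two numbers measured so far; the step of a 16-fold higher number from compound 1 to compound 2 (1.21 log units; beyond the scatter) is the only one known. Compound 3 `N#Cc1ccccc1Cc1cnc(CCc2ccc(-c3ccccc3C(=O)O)cc2)[nH]1` is the next case: 2-cyanophenyl in place of propyl on a saturated chain carbon bound to an aromatic carbon. Within the data shown here, the one measured step bears on it only loosely, since it compares a ring with a chain on the same carbon, yet it shows that a ring on that carbon in compound 1 went with a markedly lower number than the propyl of compound 2. Compound 3 again places a ring there, so the step of a 4.7-fold lower number from compound 2 to compound 3 (0.67 log units; beyond the scatter) is expected to be downward. Compound 3 is therefore estimated at 20 nM, within a range of 5 nM to 80 nM.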

Compound 3, half-maximal effective concentration: 642 nM
Beside the measured number, compound 3's estimate is 32-fold (1.51 log units) below it; the measured number lies above the stated range.
By their numbers in this assay, from the lowest: compound 1; then compound 2; then compound 3.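

In this assay, the change from propyl to 2-cyanophenyl gives a 6.9-fold higher number from compound 2 to compound 3 (0.84 log units; beyond the scatter), so a ring on this saturated chain carbon does not by itself go with a lower number, which compound 1 alone could not show. The two rings measured at this place also differ widely, with a 110-fold higher number from compound 1 to compound 3 (2.05 log units; beyond the scatter), and the propyl of compound 2 lies between them, so the presence of a ring does not set the order among these three compounds; what matters at this carbon is which group stands there, a six-membered aromatic ring with a nitrile behaving very differently from a cycloheptyl. Nothing available accounts for this result.

The compounds shown leave open whether the higher number of compound 3 goes with the aromatic ring itself or with its nitrile, a question that an unsubstituted phenyl on the same carbon would separate. They also leave open how a cyclohexyl or a longer chain such as hexyl would stand relative to cycloheptyl and propyl at this position.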